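The compounds below may be only part of what the source reports. "The series", "measured", "known", "first", "only" and "open" are said of these compounds alone.

Measured so far in a functional assay on HCT-116 cells (Homo sapiens) for cytotoxicity, read by sulforhodamine B assay, with stated times of 4 h and 5 days; a lower number here means a stronger inhibitor, a higher number a weaker inhibitor:
compound 1 `O=C(O)CCNS(=O)(=O)Cn1ccnc1[N+](=O)[O-]`, 4400000 nM
compound 2 `O=[N+]([O-])c1cncn1CCS(=O)(=O)NCCO`, 5300000 nM
compound 3 `COCCCNS(=O)(=O)CCn1c([N+](=O)[O-])cnc1C`, 3700000 nM

Compound 3 has the lowest of the three numbers, but its nearest neighbour, compound 1, and its furthest, compound 2, both sit within the usual scatter of this assay, so no ordering among the three is supported and none of them can be called the most active.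

Compound 4 `Cc1ncc([N+](=O)[O-])n1CCS(=O)(=O)NCCO` has not yet been measured. It differs from compound 3 in one place: hydroxy in place of methoxymethyl on a saturated chain carbon, two bonds along the chain from a sulfonamide nitrogen. Among the compounds with values here, no pair of measured compounds isolates this change on its own. Compound 2 carries the same hydroxyethyl sulfonamide end as compound 4, but it also differs from compound 4 elsewhere on the core, so its number is only a rough pointer.

The expectation for the step of a 1.2-fold higher number from compound 3 to compound 4 (0.09 log units; within the scatter) is therefore none beyond the scatter, with at most a slight drift toward a higher number, in line with compound 2 giving 5300000 nM while compound 3 gives 3700000 nM. Compound 4 is estimated at 4500000 nM, with a range from 2500000 nM to 8500000 nM.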

Compound 4, half-maximal inhibitory concentration: 400000 nM
Compound 4: middle estimate off by 11-fold (1.05 log units), on the high side; measured number below the stated range.
By their numbers in this assay, from the lowest: compound 4; then compounds 3, 1 and 2 (each within the scatter of the next).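

In this assay, replacing the (3-methoxypropyl)amino end with the (2-hydroxyethyl)amino end gives a 9.3-fold lower number from compound 3 to compound 4 (0.97 log units; beyond the scatter), the first sign that this stretch of the sulfonamide chain can move the number beyond the scatter, which the three earlier compounds, all within the scatter of each other, could not show. The hydroxyethyl end alone does not carry the low number: with that end held constant, methyl in place of hydrogen on an aromatic carbon gives a 13-fold lower number from compound 2 to compound 4 (1.12 log units; beyond the scatter), so the low number of compound 4 depends on the aromatic methyl as well as on the chain end. No measured property of these compounds bears on the origin of either step.

The change from compound 3 to compound 4 removes the methyl ether and shortens the chain together, so the compounds shown do not separate the hydroxy group from chain length; a 3-hydroxypropyl or 2-methoxyethyl end on the sulfonamide nitrogen would separate the two. Also open, going by these compounds, is whether the aromatic position tolerates anything larger than methyl, such as ethyl, and whether a primary amine at the chain end behaves like the hydroxy group.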